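Adding a butoxy group to a cytotoxic compound

The source may report more compounds than this note shows. Statements on the series, on what has been measured and on what is new or still open speak of the compounds shown alone.

- compound 1 `Cc1cccc(C[C@H]2C(=O)OC[C@@H]2Cc2ccccc2)c1` gives 53000 nM
- compound 2 `Clc1ccc(C[C@H]2COC[C@@H]2Cc2ccccc2)cc1Cl` gives 19000 nM
- compound 3 `O=C1OC[C@H](Cc2ccc(F)c(F)c2)[C@H]1Cc1ccc(Cl)c(Cl)c1` gives 25000 nM

All three numbers come from a functional assay on HL-60 cells (Homo sapiens) for cytotoxicity, read by WST assay, with a stated time of 48 h; a higher number here means that more compound is needed for the effect, a lower number that less compound is needed. Compound 2 (19000 nM) lies within the usual scatter of compound 3 (25000 nM), while compound 1 (53000 nM) has a higher number than compound 2, and that gap is beyond the scatter.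

Compound 4 `CCCCOc1ccccc1C[C@H]1COC[C@@H]1Cc1ccc(Cl)c(Cl)c1` has not been measured. It differs from compound 2 in one place (butoxy in place of hydrogen on an aromatic carbon): butoxy replaces hydrogen on an aromatic carbon, ortho to a large group.

Among the measured compounds shown here, no two measured compounds differ in just one place, so the data offer no direct guide to the effect of this change. The expectation in this assay is therefore tentative: a modest step towards a lower number, slightly beyond the scatter. The estimated step is a 2.4-fold lower number from compound 2 to compound 4 (0.38 log units; beyond the scatter) and it points towards less compound being needed. The expected value for compound 4 is 8000 nM (estimated range 3000 nM to 22000 nM).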

Compound 4, half-maximal effective concentration: 20000 nM
For compound 4 the middle estimate is 2.5-fold (0.40 log units) below the measured one, and the stated range covers the measured number.
By their numbers in this assay, from the lowest: compounds 2, 4 and 3 (each within the scatter of the next); then compound 1.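

In this assay butoxy in place of hydrogen on an aromatic carbon, ortho to a large group, gives a 1.1-fold higher number from compound 2 to compound 4 (0.02 log units; within the scatter) and so leaves compound 2 and compound 4 indistinguishable. Among the compounds shown here, this is the first direct reading of this change, and it shows that this position can carry a butoxy chain without a difference that rises above the scatter. Nothing measured on these compounds speaks to why the pair reads alike.

This single pair leaves open whether a shorter chain such as methoxy, or a different kind of group such as an amine or a carboxylic acid, would also read alike at this position. It also leaves open whether butoxy would give the same result on another aromatic carbon of the ring or on the core of compound 3.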